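The source may report more compounds than this note shows. Statements on the series, on what has been measured and on what is new or still open speak of the compounds shown alone.

Measured so far in an ADME assay on Huh7.5.1 cells (Homo sapiens) for cytotoxicity, read by ATP content, with a stated time of 48 h; on this read-out higher numbers stand for lower toxicity in this test and lower numbers for higher toxicity in this test:
compound 1 `Cc1oc(-c2c(C)c(C)c(C)c(C)c2C)nc1CN1CCC(C(=O)NCCCN2C[C@H](C)C[C@H](C)C2)CC1` — 8180 nM
compound 2 `Cc1ccccc1-c1nc(CN2CCC(C(=O)N3CCN(C4CCN(C)CC4)CC3)CC2)c(C)o1` — 19900 nM

Compound 1 stands at the lowest of the two numbers; compound 2 gives the nearest value, and that gap is beyond the scatter. Compound 3 `COc1cccc(F)c1-c1nc(CN2CCC(C(=O)NCCCN3C[C@H](C)C[C@H](C)C3)CC2)c(C)o1` is not yet measured. It differs from compound 1 by 2-fluoro-6-methoxyphenyl in place of 2,3,4,5,6-pentamethylphenyl on an aromatic carbon. Going by the values given here, no measured pair shows this change, so its effect can only be guessed; the expectation is a modest step upward in this assay from compound 1 to compound 3, a 1.7-fold higher number from compound 1 to compound 3 (0.23 log units; within the scatter), though a result within the scatter would not surprise. The estimate for compound 3 is 14000 nM, ranging from 6000 nM to 35000 nM.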

Compound 3, half-maximal cytotoxic concentration: 37000 nM
For compound 3 the middle estimate is 2.6-fold (0.42 log units) below the measured one; the whole stated range lies below it.
By their numbers in this assay, from the lowest: compound 1; then compounds 2 and 3 (each within the scatter of the next).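

In this assay, the aromatic carbon of the five-membered aromatic ring with 1 nitrogen and 1 oxygen now has a readable single change: 2-fluoro-6-methoxyphenyl in place of 2,3,4,5,6-pentamethylphenyl gives a 4.5-fold higher number from compound 1 to compound 3 (0.66 log units; beyond the scatter). The aryl group at this position therefore moves this read-out. Nothing at hand gives a reason for the step.

On these data alone, whether the fluorine, the methoxy group or the loss of the methyl groups carries the step remains open. So does the value for a plain phenyl group here.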